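Swapping a Hexyl Chain for a Phenyl Group

The source may report more compounds than this note shows. Statements on the series, on what has been measured and on what is new or still open speak of the compounds shown alone.

- compound 1 `CC(C)CCN(CCCCCCC(=O)NO)c1ncc(C(=O)NCc2cccnc2)s1`: 7000 nM
- compound 2 `O=C(CCCCCCCN(Cc1ccc(F)cc1)c1ncc(C(=O)NCCCn2ccnc2)s1)NO`: 26000 nM
- compound 3 `CC(C)CCN(CCCCCC(=O)NO)c1ncc(C(=O)NCCCn2ccnc2)s1`: 106000 nM
- compound 4 `O=C(/C=C/c1ccc(CN(Cc2ccc(F)cc2)c2ncc(C(=O)NCCCn3ccnc3)s2)cc1)NO`: not yet measured

In a functional assay on HepG2 cells (Homo sapiens) for inhibition, read by MTT assay, with a stated time of 72 h (on this read-out lower numbers stand for stronger inhibition and higher numbers for weaker inhibition), compound 2 gives 26000 nM, the middle of the three numbers, with clear gaps to compound 1 and compound 3. Compound 4 keeps the rest of compound 2 but carries 4-(2-(hydroxycarbamoyl)ethenyl)phenyl in place of 6-(hydroxycarbamoyl)hexyl on a saturated chain carbon bound to a nitrogen on an aromatic ring. For the measured compounds named here, no two measured compounds differ in only one place, so no direct precedent exists for this swap. Still, compound 1 at 7000 nM shows that lower numbers occur among these compounds, so a modest move downward is expected, with wide uncertainty. The expected change is a 2.6-fold lower number from compound 2 to compound 4 (0.41 log units; beyond the scatter). Compound 4 is estimated at 10000 nM, within a range of 2000 nM to 40000 nM.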

Compound 4, half-maximal inhibitory concentration: 13000 nM
Compound 4: middle estimate off by 1.3-fold (0.11 log units), on the low side; low and high end bracket the measured number.
By their numbers in this assay, from the lowest: compounds 1, 4 and 2 (each within the scatter of the next, the first and the last beyond it); then compound 3.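

In this assay, the one-place change gives a 2.0-fold lower number from compound 2 to compound 4 (0.30 log units; within the scatter), so at this position, on a saturated chain carbon bound to a nitrogen on an aromatic ring, the two groups cannot be told apart. A flexible chain and a carbon-only aromatic ring carrying a double bond can therefore both stand here without a step beyond the scatter. Nothing at hand explains this result. Still open, as far as these compounds go, is how the ring and the double bond each count alone, which 4-(2-(hydroxycarbamoyl)ethyl)phenyl could separate. Also open, from the compounds shown here alone, is how a carboxylic acid would read in place of the hydroxycarbamoyl group.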